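Diaryl urea series: trifluoromethyl to dichloro swap on the terminal phenyl

The source may report more compounds than this note shows. Statements on the series, on what has been measured and on what is new or still open speak of the compounds shown alone.

Measured so far:
compound 1 `COc1cc2cc(Oc3ccc(NC(=O)Nc4ccccc4)cc3)c(C)nc2cc1OC` gives 92.4% in a functional assay on UACC-257 cells (Homo sapiens) for inhibition, read by sulforhodamine B assay, with a stated time of 48 h, tested at 10 uM; on this read-out higher numbers stand for a weaker effect at the one concentration tested and lower numbers for a stronger effect
compound 2 `COc1cc2cc(Oc3ccc(NC(=O)Nc4cccc(C(F)(F)F)c4)cc3)c(C)nc2cc1OC` gives -14.5% in this assay

Compound 2 stands lowest of the two numbers; its nearest neighbour is compound 1, and the step of a number 106.9 percentage points lower from compound 1 to compound 2 (beyond the scatter) lies beyond the scatter. Compound 3 `COc1cc2cc(Oc3ccc(NC(=O)Nc4ccc(Cl)c(Cl)c4)cc3)c(C)nc2cc1OC` is not yet measured. It differs from compound 2 at the terminal aryl group on the urea: 3,4-dichlorophenyl in place of 3-(trifluoromethyl)phenyl on an amide-type nitrogen. For the measured compounds named here, the only measured step bears on this change indirectly: it shows that a single substituent on that aryl ring moved the read-out strongly, yet it does not compare two substituted rings. The estimate for compound 3 is therefore anchored on compound 2, with a wide range: an expected step of a number 19.5 percentage points higher from compound 2 to compound 3 (beyond the scatter), that is, an expected value of 5%, between -25% and 45%.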

Compound 3, a percentage reported as activity, at one concentration (the size of the read-out at that concentration, not a potency): 1.38%
Compound 3: middle estimate off by 3.6 percentage points, on the high side, and the stated range covers the measured number.
By their numbers in this assay, from the lowest: compound 2; then compound 3; then compound 1.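

In this assay, 3,4-dichlorophenyl in place of 3-(trifluoromethyl)phenyl on the amide-type nitrogen gives a number 15.9 percentage points higher from compound 2 to compound 3 (beyond the scatter), a modest step that separates two substituted rings, a comparison the earlier pair could not offer. Measured against the unsubstituted phenyl, the same ring gives a number 91 percentage points lower from compound 1 to compound 3 (beyond the scatter), so among these compounds the large fall in the read-out is not confined to the trifluoromethyl-bearing ring. No available measurement explains the gap between the two substituted rings.

As far as these compounds go, whether a lone chlorine, an amine or a carboxylic acid on the terminal phenyl would keep the read-out near these low numbers remains open. Also open is whether the order of these compounds would hold in other cell lines or at other concentrations.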